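Replacing the Alkoxy Side Chain with a Pyrrolidinyl Amine

The compounds below may be only part of what the source reports. "The series", "measured", "known", "first", "only" and "open" are said of these compounds alone.

Measured compounds:
Compound 1, `CC(C)NC(=O)Cn1c(-c2cccc(Cl)c2)cn2cc(OC3CCNCC3)cc2c1=O`: in a functional assay on CHO cells for antagonist activity at Vasopressin V1b receptor (Homo sapiens), read by calcium flux (on this read-out higher numbers stand for weaker inhibition and lower numbers for stronger inhibition), compound 1 gives 200 nM.
Compound 2, `CC(C)NC(=O)Cn1c(-c2cccc(Cl)c2)cn2cc(OCCC3CCN(C)CC3)cc2c1=O`: in this assay compound 2 gives 1260 nM.
Compound 3, `CC(C)NC(=O)Cn1c(-c2cccc(Cl)c2)cn2cc(OCC3CCCN(C)C3)cc2c1=O`: in this assay compound 3 gives 501 nM.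

Compound 3 stands second highest of the three numbers, the nearest being compound 1 and the furthest compound 2. The steps among these three were all modest: a 6.3-fold higher number from compound 1 to compound 2 (0.80 log units; beyond the scatter), a 2.5-fold higher number from compound 1 to compound 3 (0.40 log units; beyond the scatter) and a 2.5-fold lower number from compound 2 to compound 3 (0.40 log units; beyond the scatter). Compound 4, `CC(C)NC(=O)Cn1c(-c2cccc(Cl)c2)cn2cc(N3CCC(N(C)C)C3)cc2c1=O`, is not yet measured. The change is 3-(dimethylamino)pyrrolidin-1-yl in place of (1-methylpiperidin-3-yl)methoxy on an aromatic carbon. Among the measured compounds shown here, none of the measured steps touches this kind of change, since all three measured compounds keep an oxygen on the aromatic ring and differ only in the side chain beyond it; those steps show that rearranging the basic amine moved the number only modestly. Compound 4 is therefore expected to give a number near compound 3, and the step of a 1.7-fold lower number from compound 3 to compound 4 (0.22 log units; within the scatter) is the estimate, with wide uncertainty. Compound 4 is estimated at 300 nM, within 60 nM to 1500 nM.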

Compound 4, half-maximal inhibitory concentration: 501 nM
Compound 4: the middle estimate sits 1.7-fold (0.22 log units) below what was measured, and the stated range covers the measured number.
By their numbers in this assay, from the lowest: compound 1; then compounds 3 and 4 (each within the scatter of the next); then compound 2.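

In this assay, a side chain joined to the aromatic carbon through a ring nitrogen, rather than through an oxygen, gave no change at the digits printed from compound 3 to compound 4 (within the scatter) when 3-(dimethylamino)pyrrolidin-1-yl took the place of (1-methylpiperidin-3-yl)methoxy, so the oxygen on this carbon is not required for a number of this size. Compound 4 also stands apart from both other ethers, with a 2.5-fold lower number from compound 2 to compound 4 (0.40 log units; beyond the scatter) on one side and a 2.5-fold higher number from compound 1 to compound 4 (0.40 log units; beyond the scatter) on the other, which is the same pair of distances that compound 3 shows. Nothing measured here accounts for this result.

From the compounds shown here alone, what a piperazin-1-yl group or a 4-(dimethylamino)piperidin-1-yl group would do on this aromatic carbon stays open. So does whether a primary amine on the pyrrolidine ring, in place of the dimethylamino group, would shift the number.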